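The source may report more compounds than this note shows. Statements on the series, on what has been measured and on what is new or still open speak of the compounds shown alone.

Measured so far:
compound 1 `CN(CCCN1CCCCC1)c1ccc(C(=O)N2CCc3ccc(OS(N)(=O)=O)cc3C2)cc1` gives 17.4% in an assay on HEK293 cells for inhibition of Steryl-sulfatase (Homo sapiens), tested at 0.1 uM; on this read-out higher numbers stand for a stronger effect at the one concentration tested and lower numbers for a weaker effect;
compound 2 `CN(C)CCCN(Cc1ccccc1)c1ccc(C(=O)N2CCc3ccc(OS(N)(=O)=O)cc3C2)cc1` gives 16.2%;
compound 3 `CN(CCN1CCCCC1)c1cccc(C(=O)N2CCc3ccc(OS(N)(=O)=O)cc3C2)c1` gives 24.5%.

Compound 2 sits at the low end of these three numbers, yet compound 1 and compound 3 both lie within the usual scatter of it, so the three cannot be told apart. Compound 4 `NS(=O)(=O)Oc1ccc2c(c1)CN(C(=O)c1ccc(N(CCCO)Cc3ccccc3)cc1)CC2` has not been measured. It differs from compound 2 in one place: hydroxy in place of dimethylamino on a saturated chain carbon, three bonds along the chain from a nitrogen on an aromatic ring. Going by the values given here, no measured pair shows this change, so there is nothing to say how large its effect might be. With all three measured numbers close together, the step is expected to stay within the scatter, with no clear direction. Compound 4 is therefore estimated at 14%, between 4% and 26%, an expected step of a number 2.2 percentage points lower from compound 2 to compound 4 (within the scatter).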

Compound 4, a percentage reported as inhibition, at one concentration (the size of the read-out at that concentration, not a potency): 5.7%
Compound 4: middle estimate off by 8.3 percentage points, on the high side; the measured number falls inside the stated range.
By their numbers in this assay, from the lowest: compound 4; then compounds 2, 1 and 3 (each within the scatter of the next).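

Moving from 3-(dimethylamino)propyl to 3-hydroxypropyl gives a number 10.5 percentage points lower from compound 2 to compound 4 (beyond the scatter) in this assay and is the only single-place change here with a step beyond the scatter. The end of this chain is therefore a place where the read-out can respond to a change of group, although one pair cannot show how general that response is. No available measurement accounts for the step.

From the compounds shown here alone, whether a methoxy group or a carboxylic acid at the same chain end would fall nearer compound 2 or compound 4 remains open. A longer chain carrying the hydroxy group is equally unresolved.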